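A few compounds are considered here, and "the series" means these few. Any claim that something is new, unique, unknown or untested is made for them only; others in the source may bear on it.

In an ADME assay on MT4 cells (Homo sapiens) for cytotoxicity, read by MTT assay, with a stated time of 4 days (on this read-out lower numbers stand for higher toxicity in this test and higher numbers for lower toxicity in this test), compound 3 `Cc1cnc(Nc2ccc(C#N)cc2)nc1Oc1ccc2cc(C#N)ccc2c1Br` gives > 274000 nM, which is a limit of the assay and not a number. Compound 2 `Cc1cnc(Nc2ccc(C#N)cc2)nc1Oc1ccc2cc(C#N)ccc2c1` gives > 331000 nM in this assay, likewise a limit. Compound 1 `COc1cc2cc(C#N)ccc2c(OC)c1Oc1ccnc(Nc2ccc(C#N)cc2)n1` gives > 118000 nM in this assay, again a limit. Since every value in the series is a limit, compound 3 cannot be ordered against the other two; it simply shows no cytotoxicity up to the concentration tested. Compound 4 `N#Cc1ccc(Nc2nccc(Oc3ccc4cc(C#N)ccc4c3Br)n2)cc1` differs from compound 3 by hydrogen in place of methyl on an aromatic carbon. Within the data shown here, the one measured single-change step, a step that the two limits leave unreadable from compound 2 to compound 3, is unreadable between two limits, and no measured step covers removal of a methyl. The expected step is an at least 1.0-fold lower number from compound 3 to compound 4 (0.03 log units; that floor lies within the scatter), nothing beyond the scatter, most likely ending at a limit again. Compound 4 is estimated at 250000 nM, range 100000 nM to 600000 nM.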

Compound 4, half-maximal cytotoxic concentration: 283000 nM
Estimate against measurement, compound 4: 1.1-fold (0.05 log units) below; measured number inside the range.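

The step from compound 3 to compound 4 cannot be read, because compound 3 stands at a limit of the assay and not a number: the limit of > 274000 nM in this assay, at which 1 of the 4 values shown sits.

On these data alone, whether hydrogen in place of methyl changes the cytotoxic concentration at all stays open.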